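Swapping ethoxy for amino on a chalcone-type stilbene

The source may hold more compounds than are shown below. What is called first, only, known or untested is meant among the compounds shown, and "the series" means these compounds.

Measured compounds:
- compound 1, `CCOc1ccc(C(=O)/C=C/c2c(/C=C/c3ccc(OC)cc3)cc(OC)cc2OC)cc1`: 8 ug/mL
- compound 2, `COc1ccc(/C=C/c2cc(OC)cc(OC)c2/C=C/C(=O)c2ccccc2)cc1`: 6.8 ug/mL
- compound 3, `CCCCCCOc1ccc(C(=O)/C=C/c2c(/C=C/c3ccc(OC)cc3)cc(OC)cc2OC)cc1`: 16.2 ug/mL

These three compounds were tested in a functional assay on HepG2 cells (Homo sapiens) for antiproliferative activity, read by MTT assay, with a stated time of 48 h; on this read-out lower numbers stand for stronger inhibition and higher numbers for weaker inhibition. Compound 1 stands second highest of the three numbers; its nearest neighbour is compound 2, a 1.2-fold lower number from compound 1 to compound 2 (0.07 log units; within the scatter), and its furthest is compound 3, a 2.0-fold higher number from compound 1 to compound 3 (0.31 log units; beyond the scatter). The step of a 2.4-fold higher number from compound 2 to compound 3 (0.38 log units; beyond the scatter) points the same way.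

Compound 4, `COc1ccc(/C=C/c2cc(OC)cc(OC)c2/C=C/C(=O)c2ccc(N)cc2)cc1`, has not yet been measured. Relative to compound 1 the change is amino in place of ethoxy on an aromatic carbon. Going by the values given here, two measured steps touch the same aromatic carbon: removing the ethoxy altogether gave a 1.2-fold lower number from compound 1 to compound 2 (0.07 log units; within the scatter), which is within the scatter, while lengthening it to hexyloxy gave a 2.0-fold higher number from compound 1 to compound 3 (0.31 log units; beyond the scatter), a modest rise. Among the compounds with values here, no measured compound carries a hydrogen-bond donor at this place, so there is no direct precedent for an amino group. Since removing the ethoxy changed little, the expectation is a step of about a 1.1-fold lower number from compound 1 to compound 4 (0.03 log units; within the scatter), that is, none beyond the scatter. Compound 4 is therefore estimated to give 7.5 ug/mL, with a range from 3.5 ug/mL to 16 ug/mL.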

Compound 4, half-maximal inhibitory concentration: 7.5 ug/mL
The estimate for compound 4 equals the measured number at the digits printed, within the range that was stated.
By their numbers in this assay, from the lowest: compounds 2, 4 and 1 (each within the scatter of the next); then compound 3.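

Compound 4 is the only compound shown with a hydrogen-bond donor on this aromatic carbon, yet in this assay the change from ethoxy to amino gives a 1.1-fold lower number from compound 1 to compound 4 (0.03 log units; within the scatter) and so leaves the number in place. Set against the bare ring, the amino group gives a 1.1-fold higher number from compound 2 to compound 4 (0.04 log units; within the scatter) and this also shows no change, so hydrogen, amino and ethoxy cannot be told apart at this position, even though they differ in size and only amino carries a donor. Hexyloxy is the one group that stands apart among these four, and replacing it with amino gives a 2.2-fold lower number from compound 3 to compound 4 (0.33 log units; beyond the scatter) as a modest step, which now makes compound 3 differ from all three of the others at this carbon.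

Still open, from the compounds shown here alone, is whether a butoxy chain, a carboxylic acid or a dimethylamino group on this carbon would read like compounds 1, 2 and 4 or like compound 3, and at what chain length between ethoxy and hexyloxy the number begins to rise. Nothing measured here explains why these three groups read alike while hexyloxy does not.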